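This account rests on a few compounds, and the source may have more. Where it says the series, first, only, none or still open, it means among the compounds named here.

Of the compounds shown here, three have so far been tested in a functional assay on the whole organism (strain albino) for inhibition, with Rattus norvegicus as the target, read by paw edema, with stated times of 30 min and 4 h, at a dose of 25 mg/kg by the intraperitoneal route; on this read-out higher numbers stand for more inhibition at the one dose given (going by the name of the read-out) and lower numbers for less inhibition. Compound 1 `CCOC(=O)c1nn(-c2ccccc2)c(-c2ccc(OC)cc2OC)c1-c1ccccc1` gives 20.2% in this assay. Compound 2 `CCOC(=O)C(=O)C(C)C(=O)c1ccc(OC)cc1OC`, built quite differently from the other two, gives 24.6%. Compound 3 `CCOC(=O)c1nn(-c2ccc(Cl)cc2)c(-c2ccc(OC)cc2OC)c1-c1ccccc1` gives 15.4%. Compound 3 thus holds the lowest of the three numbers, yet its distance to compound 1 and its distance to compound 2 both lie within the usual scatter of repeated measurements, so no real order among the three can be read from these figures. For the measured compounds named here, the only measured step between compounds that differ in a single place is a number 4.8 percentage points lower from compound 1 to compound 3 (within the scatter), and that too falls within the scatter.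

Compound 4 `COc1ccc(-c2c(-c3ccccc3)c(C(=O)O)nn2-c2ccc(Cl)cc2)c(OC)c1` differs from compound 3 in one place: hydrogen in place of ethyl on an oxygen next to a carbonyl group. Going by the values given here, no measured step touches this oxygen. Among the compounds with values here, the one step on hand, which exchanges chloro for hydrogen on an aromatic carbon, concerns a different part of the molecule and is itself small, so there is nothing to suggest a move in either direction here. The step expected from this change, a number 1.6 percentage points higher from compound 3 to compound 4 (within the scatter), is therefore none beyond the scatter. Compound 4 is expected to give 17%, with a plausible range from 5% to 30%.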

Compound 4, a percentage reported as inhibition, in the whole organism at one dose (the size of the read-out at that dose, not a potency): 42.5%
Beside the measured number, compound 4's estimate is 25.5 percentage points below it; the whole stated range lies below it.
By their numbers in this assay, from the lowest: compounds 3, 1 and 2 (each within the scatter of the next); then compound 4.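

Exchanging ethyl for hydrogen on the oxygen next to a carbonyl group, which turns ethoxycarbonyl into carboxy, gives a number 27.1 percentage points higher from compound 3 to compound 4 (beyond the scatter) in this assay at the one dose tested. This is the first step in the series to stand clear of the scatter, whereas the exchange of chloro for hydrogen on an aromatic carbon, a number 4.8 percentage points lower from compound 1 to compound 3 (within the scatter), does not, so this oxygen is the first place shown where one small change clearly moves the read-out. No measurement at hand explains why the number moves with this change.

From the compounds shown here alone, whether the free carboxy group itself is what counts remains open, and a primary amide, a methyl ester or a longer chain on the same oxygen would help separate the presence of the free hydrogen from the size of the group that replaces it. Also open, going by these compounds, are whether the same exchange on compound 1 would give a step of similar size, and whether the difference would hold at other doses, since a single dose describes the size of the effect and not a potency.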